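A few compounds are considered here, and "the series" means these few. Any claim that something is new, unique, unknown or untested is made for them only; others in the source may bear on it.

Three compounds have been measured in a functional assay on SW480 cells (Homo sapiens) for antiproliferative activity, read by sulforhodamine B assay, with a stated time of 48 h; on this read-out higher numbers stand for weaker inhibition and lower numbers for stronger inhibition:

Compound 1 `COc1ccc(/C=C/C(=O)c2ccccc2-c2ccc(OC)c(OC)c2)cc1OC` gives 7600 nM.
Compound 2 `COc1ccc(OC)c(/C=C/C(=O)c2ccccc2-c2ccc(OC)c(OC)c2)c1` gives 5200 nM.
Compound 3 `COc1ccc(/C=C/C(=O)c2ccccc2-c2ccc(F)cc2)cc1OC` gives 570 nM.

Compound 1 and compound 2 share all their atoms, joined differently; the difference is 2,5-dimethoxyphenyl in place of 3,4-dimethoxyphenyl on a double-bonded chain carbon bound to a double-bonded chain carbon. In this assay this gives a 1.5-fold lower number from compound 1 to compound 2 (0.16 log units; within the scatter), so the two cores cannot be told apart on this read-out.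

Compound 3 arises from compound 1 by a different change, (4-fluorophenyl in place of 3,4-dimethoxyphenyl on an aromatic carbon). Here this assay shows a 13-fold lower number from compound 1 to compound 3 (1.12 log units; beyond the scatter), the one clear movement among the three measured compounds.

Compound 4 `COc1ccc(OC)c(/C=C/C(=O)c2ccccc2-c2ccc(F)cc2)c1` has not yet been measured. It stands to compound 2 as compound 3 stands to compound 1: the change is 4-fluorophenyl in place of 3,4-dimethoxyphenyl on an aromatic carbon, and the place of the change is described in the same words in both pairs, so it is the same change made on the other core. Among the measured compounds shown here, the only guide to its size is the single earlier step, a 13-fold lower number from compound 1 to compound 3 (1.12 log units; beyond the scatter), and the two cores differ by an amount within the scatter, a 1.5-fold lower number from compound 1 to compound 2 (0.16 log units; within the scatter), so the step is expected to carry over. On that basis compound 4 is expected to show a 12-fold lower number from compound 2 to compound 4 (1.06 log units; beyond the scatter) in this assay. Compound 4 is therefore estimated at 450 nM, with a range from 150 nM to 1500 nM, resting on one prior example only.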

Compound 4, half-maximal inhibitory concentration: 2400 nM
The estimate for compound 4 lay 5.3-fold (0.73 log units) below the measured number, and the stated range ends below it.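

In this assay, putting 4-fluorophenyl in place of 3,4-dimethoxyphenyl on the core of compound 2 gives a 2.2-fold lower number from compound 2 to compound 4 (0.34 log units; beyond the scatter), so the number falls on both cores, but the size of the step does not carry from one core to the other: the same change on two cores in this assay, a 13-fold lower number (1.12 log units; beyond the scatter) from compound 1 to compound 3 and a 2.2-fold lower number (0.34 log units; beyond the scatter) from compound 2 to compound 4, 6.2-fold (0.79 log units) apart, beyond the scatter of two such steps The direction of this change therefore held in the one transfer available here, while its size depended on whether the other aryl group was the 3,4-dimethoxyphenyl of compound 1 or the 2,5-dimethoxyphenyl of compound 2, even though those two cores could not be told apart when they carried 3,4-dimethoxyphenyl. Among the compounds shown here, with only two pairs, this does not show how the step would behave on any further core, nor why it differs, and it cannot separate the loss of the two methoxy groups from the arrival of the fluorine, since the whole group is exchanged at once.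

Going by these compounds, it remains open whether a plain phenyl, a 4-chlorophenyl or a 4-methoxyphenyl group at the same place would follow the larger step or the smaller one. On these data alone, it is also open whether a third core, such as one bearing a single methoxy group or a trimethoxyphenyl group on the chain, would keep the same direction for this change.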